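Cyclohexylmethyl for phenyl: cytotoxicity notes on two cores

This account rests on a few compounds, and the source may have more. Where it says the series, first, only, none or still open, it means among the compounds named here.

Compound 1 `CN1Cc2ccc(O)cc2[C@@H](OCc2ccccc2)C1` and compound 2 `CN1Cc2ccc(O)cc2[C@@H](OCCC2CCCCC2)C1` share one core and differ by cyclohexylmethyl in place of phenyl on a saturated chain carbon bound to an oxygen on a saturated carbon. In an ADME assay on Vero cells (Chlorocebus sabaeus) for cytotoxicity, read by sulforhodamine B assay, with a stated time of 72 h (a higher number here means a weaker inhibitor, a lower number a stronger inhibitor), compound 1 gives only a limit, > 50000 nM. In this assay compound 2 likewise gives only a limit, > 50000 nM. The step that the two limits leave unreadable from compound 1 to compound 2 is therefore not readable, both values resting at the limit of > 50000 nM in this assay, at which 2 of the 3 values shown sit.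

Compound 3 `CN1Cc2c(OCc3ccccc3)cccc2[C@@H](O)C1` carries the same atoms as compound 1 joined differently; the difference between the two cores is not broken down here. In this assay compound 3 gives only a limit, > 100000 nM, which is the limit of > 100000 nM in this assay, at which 1 of the 3 values shown sits.

Compound 4 `CN1Cc2c(OCCC3CCCCC3)cccc2[C@@H](O)C1`, not yet measured, arises from compound 3 by cyclohexylmethyl in place of phenyl on a saturated chain carbon bound to an oxygen on an aromatic ring. This is the same kind of change as that from compound 1 to compound 2, but the place differs: there the group sits on a saturated chain carbon bound to an oxygen on a saturated carbon, here on a saturated chain carbon bound to an oxygen on an aromatic ring.

Among the measured compounds shown here, the expected step is a step that the limit leaves unreadable from compound 3 to compound 4, set beside a step that the two limits leave unreadable from compound 1 to compound 2, and it rests on a weak footing because compound 3 sits at the limit of > 100000 nM in this assay, at which 1 of the 3 values shown sits, and no numeric step is available. Compound 4 is estimated at 150000 nM, with a range from 60000 nM to 400000 nM, most likely reported as a limit again.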

Compound 4, half-maximal inhibitory concentration: 62700 nM
Estimate against measurement, compound 4: 2.4-fold (0.38 log units) above; the measured number falls inside the stated range.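

On the core of compound 3, cyclohexylmethyl in place of phenyl gives in this assay an at least 1.5-fold lower number from compound 3 to compound 4 (0.20 log units; that floor lies within the scatter), which sets a floor on the step and does not measure its size. Compound 3 gives only a limit, not a number: the limit of > 100000 nM in this assay, at which 1 of the 4 values shown sits. The same change on the core of compound 1 cannot be read, since both of its ends are limits, so the notes show neither that the step carries from one core to the other nor that it fails to carry: the limit of > 50000 nM in this assay, at which 2 of the 4 values shown sit.

Going by these compounds, compound 4 alone has a numeric value, 62700 nM, and whether the step on its core goes beyond the scatter stays open. Also open, on these data alone, is what a carboxylic acid, an amine or a longer chain in place of cyclohexylmethyl would give on either core in this assay.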